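The compounds below may be only part of what the source reports. "The series", "measured", "known", "first", "only" and "open" are said of these compounds alone.

Series notes. In a functional assay on HOP-62 cells (Homo sapiens) for inhibition, read by sulforhodamine B assay, with a stated time of 48 h (on this read-out lower numbers stand for higher toxicity in this test and higher numbers for lower toxicity in this test), compound 1 `Nc1cc(N)c2nc(-c3ccccc3)c(NCc3ccc(Cl)c(Cl)c3)nc2c1` gives 64600 nM. Compound 3 `COc1ccc(CNc2nc3cc(N)cc(N)c3nc2-c2ccccc2)cc1` gives 69200 nM in this assay, and the step of a 1.1-fold higher number from compound 1 to compound 3 (0.03 log units; within the scatter) lies within the scatter. Compound 2 `Nc1cc(N)c2nc(-c3ccccc3)c(NCc3ccc(F)cc3)nc2c1` is known in this assay only as a limit, < 100000 nM. Because of the limit of < 100000 nM in this assay, at which 1 of the 3 values shown sits, the steps a step that the limit leaves unreadable from compound 1 to compound 2 and a step that the limit leaves unreadable from compound 2 to compound 3 cannot be sized. Compound 4 `Nc1cc(N)c2nc(-c3ccccc3)c(Sc3ccc(Cl)c(Cl)c3)nc2c1` is not yet measured and differs from compound 2 by (3,4-dichlorophenyl)sulfanyl in place of (4-fluorobenzyl)amino on an aromatic carbon. For the measured compounds named here, no measured pair follows this change: the sulfanyl link has no counterpart among the measured compounds, and compound 2 offers no number to step from. The expected value for compound 4 is estimated at 65000 nM, within 25000 nM to 150000 nM. The step that the limit leaves unreadable from compound 2 to compound 4 is expected to be nominal only, read against a limit.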

Compound 4, concentration lethal to 50% of the cells: < 100000 nM
Compound 4: a limit, no number; the forecaster's own chance of this, stated with the estimate: 30%; the middle value is on the limit's open side.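

No new step can be read between compound 2 and compound 4, because both are known only as limits: the limit of < 100000 nM in this assay, at which 2 of the 4 values shown sit. Going by these compounds, whether (3,4-dichlorophenyl)sulfanyl in place of (4-fluorobenzyl)amino shifts the read-out in this assay stays open.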